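A few compounds are considered here, and "the series" means these few. Any claim that something is new, unique, unknown or untested is made for them only; others in the source may bear on it.

Compounds measured so far:
- compound 1 `O=C(Nc1cccc(Br)c1)N[C@H]1CC[C@H](Oc2ccc(F)cc2)CC1`: 6200 nM
- compound 2 `O=C(Nc1ccc(F)cc1)N[C@H]1CC[C@H](Oc2ccc(F)cc2)CC1`: 20000 nM

In a functional assay on CRL2813 cells (Homo sapiens) for cytotoxicity, read by sulforhodamine B assay, with a stated time of 5 days (on this read-out higher numbers stand for weaker inhibition and lower numbers for stronger inhibition), compound 1 holds the lowest of the two numbers, so it is the stronger inhibitor here. Among the compounds with values here, the single measured step was a 3.2-fold higher number from compound 1 to compound 2 (0.51 log units; beyond the scatter). Compound 3 `COC(=O)c1cccc(NC(=O)N[C@H]2CC[C@H](Oc3ccc(F)cc3)CC2)c1` differs from compound 1 by methoxycarbonyl in place of bromo on an aromatic carbon. That one step bears only loosely on this change, since it swaps a whole aromatic substituent rather than adding a methoxycarbonyl; it suggests that altering this ring tends to raise the number modestly. For compound 3 a modest weakening is therefore expected, a 1.6-fold higher number from compound 1 to compound 3 (0.21 log units; within the scatter). The estimate for compound 3 is 10000 nM, expected to lie between 3000 nM and 30000 nM.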

Compound 3, half-maximal inhibitory concentration: 9200 nM
Compound 3: middle estimate off by 1.1-fold (0.04 log units), on the high side, and the stated range covers the measured number.
By their numbers in this assay, from the lowest: compounds 1 and 3 (each within the scatter of the next); then compound 2.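

At this aromatic carbon, meta to a large group, the single bromine atom gives way to the four heavy atoms of methoxycarbonyl, with its two hydrogen-bond acceptors, and this assay shows a 1.5-fold higher number from compound 1 to compound 3 (0.17 log units; within the scatter). This position therefore accepts a larger group with no difference beyond the scatter, something the earlier pair could not show, since it changed the ring's substituent and its place together. Nothing available explains this result. Going by these compounds, whether an amine or a carboxylic acid on this same carbon would also stay within the scatter remains open.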